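Adding ethyl to the bromo compound

A few compounds are considered here, and "the series" means these few. Any claim that something is new, unique, unknown or untested is made for them only; others in the source may bear on it.

Values in a functional assay on HeLa cells (Homo sapiens) for antiproliferative activity, read by MTT assay, with a stated time of 72 h (on this read-out lower numbers stand for stronger inhibition and higher numbers for weaker inhibition), are as follows
Compound 1 `CC(=O)NNC(=O)c1csc2ncc(-c3ccc(C)cc3)n12` gives 74200 nM
Compound 2 `CCCC(=O)NNC(=O)c1csc2ncc(-c3ccc(C)cc3)n12` gives 45600 nM
Compound 3 `CC(=O)NNC(=O)c1csc2ncc(-c3ccc(Br)cc3)n12` gives 4780 nM
Compound 4 `CCCC(=O)NNC(=O)c1csc2ncc(-c3ccc(Br)cc3)n12` is not yet measured

Compound 3 (4780 nM) holds the lowest of the three numbers, beyond the scatter from both others. Compound 4 differs from it by ethyl in place of hydrogen on a saturated chain carbon bound to a carbonyl carbon and so carries ethyl in place of hydrogen on a saturated chain carbon bound to a carbonyl carbon. The same change was measured once, as a 1.6-fold lower number from compound 1 to compound 2 (0.21 log units; within the scatter) and so gives little reason to expect much here. The other measured step, a 16-fold lower number from compound 1 to compound 3 (1.19 log units; beyond the scatter) is the bromo for methyl exchange, which compound 3 already contains. In this assay the expected change is therefore small, a 1.4-fold lower number from compound 3 to compound 4 (0.14 log units; within the scatter) and not beyond the scatter. Compound 4 is expected at 3500 nM (estimated range 1700 nM to 9000 nM).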

Compound 4, half-maximal inhibitory concentration: 31900 nM
Compound 4: middle estimate off by 9.1-fold (0.96 log units), on the low side; measured number above the stated range.
By their numbers in this assay, from the lowest: compound 3; then compounds 4, 2 and 1 (each within the scatter of the next, the first and the last beyond it).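

In this assay, ethyl in place of hydrogen on a saturated chain carbon bound to a carbonyl carbon has no fixed effect: with bromo on the aromatic carbon it gives a 6.7-fold higher number from compound 3 to compound 4 (0.82 log units; beyond the scatter), so its outcome depends on the aromatic group: the same change on two cores in this assay, a 1.6-fold lower number (0.21 log units; within the scatter) from compound 1 to compound 2 and a 6.7-fold higher number (0.82 log units; beyond the scatter) from compound 3 to compound 4, 11-fold (1.04 log units) apart, beyond the scatter of two such steps The bromo for methyl exchange, in turn, gives only a 1.4-fold lower number from compound 2 to compound 4 (0.16 log units; within the scatter) once the propylcarbonyl group is present, so the two changes do not simply add: the same change on two cores in this assay, a 16-fold lower number (1.19 log units; beyond the scatter) from compound 1 to compound 3 and a 1.4-fold lower number (0.16 log units; within the scatter) from compound 2 to compound 4, 11-fold (1.04 log units) apart, beyond the scatter of two such steps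

Going by these compounds, what a methyl or an amine on this chain carbon would do in the bromo series stays open. So does whether chloro on the aromatic carbon would show the same dependence on the chain.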